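The source may report more compounds than this note shows. Statements on the series, on what has been measured and on what is new or still open speak of the compounds shown alone.

Measured in an ADME assay on NIH3T3 cells (Mus musculus) for cytotoxicity, read by XTT assay, with a stated time of 24 h (on this read-out higher numbers stand for weaker inhibition and lower numbers for stronger inhibition), each value a limit and not a number:

- compound 1 `Fc1ccc(C2CC(c3ccc(Cl)s3)=NN2c2nc(-c3ccc(Br)cc3)cs2)cc1`: > 500 ug/mL
- compound 2 `CS(=O)(=O)c1ccc(-c2csc(N3N=C(c4ccc(Cl)s4)CC3c3ccc(F)cc3)n2)cc1`: > 500 ug/mL
- compound 3 `Fc1ccc(C2CC(c3ccc(Cl)s3)=NN2c2nc(-c3ccccc3)cs2)cc1`: > 500 ug/mL

Compound 3 therefore has no exact place in the series, only a limit. The measurements so far offer only (the limit of > 500 ug/mL in this assay, at which 3 of the 3 values shown sit).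

The next compound, compound 4 `O=[N+]([O-])c1ccc(-c2csc(N3N=C(c4ccc(Cl)s4)CC3c3ccc(F)cc3)n2)cc1`, carries nitro in place of hydrogen on an aromatic carbon of a six-membered aromatic ring of carbon only, para to a large group: nitro in place of hydrogen on an aromatic carbon.

For the measured compounds named here, three measured steps bear on this change: a step that the two limits leave unreadable from compound 1 to compound 3, with hydrogen in place of bromo; a step that the two limits leave unreadable from compound 2 to compound 3, with hydrogen in place of methylsulfonyl; and a step that the two limits leave unreadable from compound 1 to compound 2, with methylsulfonyl in place of bromo. None of them has a readable size, and none gives a direction. Neither bromo nor methylsulfonyl moved the read-out off the limit, so the working expectation is that nitro will not either.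

The expected change is a number no higher from compound 3 to compound 4 (the limit leaves the size open), with nothing expected beyond the scatter in this assay and no direction expected. A report as a limit is again the likeliest outcome.

For compound 4 the estimate is 500 ug/mL, with an expected range of 250 ug/mL to 1000 ug/mL.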

Compound 4, half-maximal inhibitory concentration: > 500 ug/mL
Compound 4: no number, only a limit; the forecaster's own chance of this, stated with the estimate: 80%; the middle value sits exactly at the limit.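

In this assay compound 4 gives > 500 ug/mL, a limit and not a number. For the compounds shown here, no step from compound 1, compound 2 or compound 3 to compound 4 can be read, and all four compounds stay at one limit: the limit of > 500 ug/mL in this assay, at which 4 of the 4 values shown sit. The compounds shown leave open whether hydrogen, bromo, methylsulfonyl and nitro differ at all in this assay.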